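Swapping the benzyl halogen where every value is a limit

The compounds below may be only part of what the source reports. "The series", "measured", "known", "first", "only" and "open" are said of these compounds alone.

Compound 1 `O=C1/C(=C/c2ccccc2F)CN(C(=S)SCc2cn(Cc3ccccc3Cl)nn2)C/C1=C\c1ccccc1F` in a functional assay on PC-3 cells (Homo sapiens) for cytotoxicity, read by MTT assay, with a stated time of 24 h (on this read-out higher numbers stand for weaker inhibition and lower numbers for stronger inhibition), gives a limit, > 80000 nM.
Compound 2 `O=C1/C(=C/c2ccccc2F)CN(C(=S)SCc2cn(Cc3ccccc3F)nn2)C/C1=C\c1ccccc1F` in this assay gives a limit, > 80000 nM.
Compound 3 `O=C1/C(=C/c2ccccc2F)CN(C(=S)SCc2cn(Cc3ccc(F)cc3)nn2)C/C1=C\c1ccccc1F` in this assay gives a limit, > 80000 nM.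

Compound 3 stands where all the measured compounds stand: at the limit of this assay, with no number of its own. Compound 4 `O=C1/C(=C/c2ccccc2F)CN(C(=S)SCc2cn(Cc3cccc(Cl)c3)nn2)C/C1=C\c1ccccc1F` differs from it by 3-chlorophenyl in place of 4-fluorophenyl on a saturated chain carbon bound to an aromatic nitrogen. The measured steps that touch this position, a step that the two limits leave unreadable from compound 1 to compound 3 and a step that the two limits leave unreadable from compound 2 to compound 3, as well as a step that the two limits leave unreadable from compound 1 to compound 2, give no readable size, because of the limit of > 80000 nM in this assay, at which 3 of the 3 values shown sit. So no direction or size of step can be expected beyond the scatter, and compound 4 is expected most likely to sit at that limit again. The estimate for compound 4 in this assay is 100000 nM, ranging from 30000 nM to 300000 nM, which means an expected step that the limit leaves unreadable from compound 3 to compound 4.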

Compound 4, half-maximal inhibitory concentration: 80000 nM
Compound 4: middle estimate off by 1.3-fold (0.10 log units), on the high side; the range from low to high includes it.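

In this assay compound 4 gives 80000 nM, the only plain number among the compounds shown. This shows that 3-chlorophenyl at this position can give a readable value, but not that it strengthens inhibition. The data give a number no higher from compound 3 to compound 4 (the limit leaves the size open), a number no higher from compound 2 to compound 4 (the limit leaves the size open) and a number no higher from compound 1 to compound 4 (the limit leaves the size open). None of these steps can be read for size, because the other values are limits: the limit of > 80000 nM in this assay, at which 3 of the 4 values shown sit.

As far as these compounds go, it remains open whether a group other than a halogen-bearing phenyl, such as an amine or a carboxylic acid in place of the 3-chlorophenyl, would give a clearly lower number.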